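Swapping the carbamate alcohol side chain: expected cytotoxicity

A few compounds are considered here, and "the series" means these few. Any claim that something is new, unique, unknown or untested is made for them only; others in the source may bear on it.

Compound 1, with structure `CC(C)C[C@H](NC(=O)OC1CCC(C)(C)CC1)C(=O)N[C@@H](C[C@@H]1CCNC1=O)C(O)S(=O)(=O)O`, was tested in an ADME assay on HEK-293T cells (Homo sapiens) for cytotoxicity, with a stated time of 72 h; on this read-out higher numbers stand for lower toxicity in this test and lower numbers for higher toxicity in this test. In this assay compound 1 gives > 100000 nM, which is a limit of the test rather than a measured number. The evidence on hand is thus thin: the limit of > 100000 nM in this assay, at which 1 of the 2 values shown sits. A second compound, compound 2 with structure `CC(C)C[C@H](NC(=O)OCC1CCC(F)(F)CC1)C(=O)N[C@H](C=O)C[C@@H]1CCNC1=O`, carries no result; in this assay compound 2 stands as "not determined" (no result reported); "not determined" (no result reported) (2 entries).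

Compound 3, with structure `CCCC(OC(=O)N[C@@H](CC(C)C)C(=O)N[C@@H](C[C@@H]1CCNC1=O)C(O)S(=O)(=O)O)c1ccccc1`, has not yet been measured. The change from compound 1 is 1-phenylbutyl in place of 4,4-dimethylcyclohexyl on an oxygen next to a carbonyl group.

Among the compounds with values here, because compound 1 sits at > 100000 nM, there is no measured step to build on, and the direction of any change cannot be read from the data. The expectation is that the step from compound 1 to compound 3 is a number no higher from compound 1 to compound 3 (the limit leaves the size open), that is, none beyond the usual scatter of this assay. Compound 3 is therefore estimated at 100000 nM, with a range from 30000 nM to 300000 nM, and a fair chance that the test again reports only a limit.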

Compound 3, half-maximal cytotoxic concentration: > 100000 nM
Compound 3 ended at the assay's limit; the forecaster's own chance of this, stated with the estimate: 65%; the middle value lies on the limit itself.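

Within the data shown here, compound 1 and compound 3 both stop at the limit of the test in this assay, so no step between them can be read: the limit of > 100000 nM in this assay, at which 2 of the 3 values shown sit. The compounds shown leave open whether 1-phenylbutyl in place of 4,4-dimethylcyclohexyl changes cytotoxicity at all, and at what concentration either compound would begin to harm these cells.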